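Adding a second chloro to the core of compound 1

The compounds below may be only part of what the source reports. "The series", "measured", "known", "first", "only" and "open" are said of these compounds alone.

Of the compounds shown here, two have been measured in a functional assay on OVCAR-3 cells (Homo sapiens) for cytotoxicity, read by sulforhodamine B assay, with a stated time of 48 h; a lower number here means that less compound is tolerated, a higher number that more compound is tolerated. Compound 1 `ClCc1ccc(Cn2cnc3c(Cl)ncnc32)cc1` gives 8910 nM in this assay. Compound 2 `ClCc1cccc(Cn2cnc3c(Cl)nc(Cl)nc32)c1` gives 6450 nM in this assay, and the two numbers lie within the scatter of each other, so neither can be called the more or less tolerated of the pair.

Compound 3 `ClCc1ccc(Cn2cnc3c(Cl)nc(Cl)nc32)cc1` has not yet been measured. It differs from compound 1 in one place: chloro in place of hydrogen on an aromatic carbon. Among the compounds with values here, no two measured compounds differ in exactly one place, so no measured step guides the expectation directly; the only anchor is that both measured compounds fall close together.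

For compound 3 the change from compound 1 is therefore expected to make a step no larger than the scatter, a 1.3-fold lower number from compound 1 to compound 3 (0.10 log units; within the scatter), in this assay. Compound 3 is estimated to give about 7000 nM in this assay, within a range from 3500 nM to 14000 nM.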

Compound 3, concentration lethal to 50% of the cells: 9550 nM
The estimate for compound 3 lay 1.4-fold (0.13 log units) below the measured number; the range from low to high includes it.
By their numbers in this assay, from the lowest: compounds 2, 1 and 3 (each within the scatter of the next).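

The step for chloro in place of hydrogen on an aromatic carbon, between two ring nitrogen atoms, is a 1.1-fold higher number from compound 1 to compound 3 (0.03 log units; within the scatter) in this assay. Within the data shown here, this is the first comparison here that isolates a single place, and it shows that, for this pair, the chloro cannot be told apart from hydrogen at this position in this assay. No measurement on hand offers an explanation for this result.

From the compounds shown here alone, the finding rests on one pair and one group, so it remains open whether an amine or a methoxy group at the same position would also stay within the scatter. Going by these compounds, it is also open whether a carboxylic acid or a longer chain elsewhere on compound 3 would shift the number beyond the scatter.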